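This account rests on a few compounds, and the source may have more. Where it says the series, first, only, none or still open, it means among the compounds named here.

The three compounds share one core, and the change followed here is a single halogen swap. Compound 1 `COc1ccc2c(c1)[n+]([O-])c(C(=O)NCc1ccccc1)c(C)[n+]2[O-]` carries a methoxy group on that core; in an ADME assay on Vero cells (Chlorocebus sabaeus) for cytotoxicity, read by MTT assay, with a stated time of 72 h (on this read-out lower numbers stand for stronger inhibition and higher numbers for weaker inhibition), compound 1 is recorded as "not determined" (no result reported). Compound 2 `Cc1c(C(=O)NCc2ccccc2)[n+]([O-])c2cc(Cl)ccc2[n+]1[O-]` carries a chloro group. In this assay compound 2 gives > 100 ug/mL, which is a limit of the assay rather than a number. Compound 2 therefore stands at the limit of > 100 ug/mL in this assay, at which 1 of the 2 values shown sits, so its place among the values shown is an edge rather than a point within a spread. Compound 3 `Cc1c(C(=O)NCc2ccccc2)[n+]([O-])c2cc(F)ccc2[n+]1[O-]` is the one still to be measured; its difference from compound 2 is fluoro in place of chloro on an aromatic carbon. Among the compounds with values here, no step between measured compounds exists here, so nothing measured tells how this assay responds to a change of this kind. Compound 3 is expected to return a similar result, with an expected step of a number no higher from compound 2 to compound 3 (the limit leaves the size open) of no size beyond the scatter. Compound 3 is thus estimated at 100 ug/mL, with a range from 50 ug/mL to 200 ug/mL.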

Compound 3, half-maximal inhibitory concentration: > 100 ug/mL
Compound 3 was reported as a limit; the forecaster's own chance of this, stated with the estimate: 70%; the middle value sits exactly at the limit.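

In this assay compound 3 gives > 100 ug/mL, which is a limit of the assay and not a number. Within the data shown here, no step from compound 2 to compound 3 can be read, because both compounds stop at the same limit: the limit of > 100 ug/mL in this assay, at which 2 of the 3 values shown sit. The compounds shown leave open whether fluoro and chloro on this aromatic carbon differ at all in this read-out.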